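Amide variation on the glycine urea tail

A few compounds are considered here, and "the series" means these few. Any claim that something is new, unique, unknown or untested is made for them only; others in the source may bear on it.

Measured compounds:
- compound 1 `Cc1cc(C(=O)N2CCCCc3ccccc32)ccc1CNC(=O)NCC(=O)OC(C)C`: 140 nM
- compound 2 `Cc1cc(C(=O)N2CCCCc3ccccc32)ccc1CNC(=O)NCC(=O)OC(C)(C)C`: 120 nM
- compound 3 `Cc1cc(C(=O)N2CCCCc3ccccc32)ccc1CNC(=O)NCC(=O)N(C)C`: 58 nM

All three share the same core and differ only in the group on the carbonyl carbon of the glycine tail. In a functional assay on HEK293 cells for agonist activity at Vasopressin V2 receptor (Homo sapiens), read by a luciferase reporter and cAMP accumulation (on this read-out higher numbers stand for an effect only at larger amounts of compound and lower numbers for an effect already at smaller amounts), compound 3 gives the lowest number of the three: the step of a 2.4-fold lower number from compound 1 to compound 3 (0.38 log units; beyond the scatter) and the step of a 2.1-fold lower number from compound 2 to compound 3 (0.32 log units; beyond the scatter) are both beyond the scatter, though modest. The step of a 1.2-fold lower number from compound 1 to compound 2 (0.07 log units; within the scatter) between the two esters lies within the scatter.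

Compound 4 `Cc1cc(C(=O)N2CCCCc3ccccc32)ccc1CNC(=O)NCC(=O)N1CCCCC1` carries the change (piperidin-1-yl in place of dimethylamino on a carbonyl carbon). Among the measured compounds shown here, no measured pair covers a change from one amide to another; the nearest information is that enlarging the ester in the step from compound 1 to compound 2 did nothing beyond the scatter, while the two ester-to-amide steps each gave a modest gain. An amide-to-amide change is therefore expected to move this assay little, with no clear direction; the estimated step is a 1.0-fold higher number from compound 3 to compound 4 (0.01 log units; within the scatter). For compound 4 the expected value is 60 nM, with a range from 25 nM to 150 nM.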

Compound 4, half-maximal effective concentration: 150 nM
Compound 4: middle estimate off by 2.5-fold (0.40 log units), on the low side; the measured number falls inside the stated range.
By their numbers in this assay, from the lowest: compound 3; then compounds 2, 1 and 4 (each within the scatter of the next).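

At the carbonyl carbon of the glycine tail, one amide cannot simply be exchanged for another in this assay: piperidin-1-yl in place of dimethylamino gives a 2.6-fold higher number from compound 3 to compound 4 (0.41 log units; beyond the scatter) and so removes the advantage that compound 3 holds over the esters, which means that this advantage does not extend to every amide at this position. Compound 4 instead falls in with the two esters, with a 1.3-fold higher number from compound 2 to compound 4 (0.10 log units; within the scatter) and a 1.1-fold higher number from compound 1 to compound 4 (0.03 log units; within the scatter) both within the scatter, so that among these four compounds only the dimethylamino amide of compound 3 stands apart from the rest. No evidence at hand accounts for this difference between the two amides.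

Still open, as far as these compounds go, is whether the lower number belongs to dimethylamino alone or is shared by close relatives such as diethylamino, pyrrolidin-1-yl or azetidin-1-yl, which would show whether the ring of compound 4 or its added carbons go with the higher number. Also open, from the compounds shown here alone, is how morpholin-4-yl, a methylamino amide that keeps the amide hydrogen, or the free carboxylic acid would compare with compound 3 and compound 4 on the same tail.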